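The source may report more compounds than this note shows. Statements on the series, on what has been measured and on what is new or still open speak of the compounds shown alone.

Measured in a functional assay on HCT-116 cells (Homo sapiens) for inhibition, read by MTT assay, with a stated time of 72 h; on this read-out lower numbers stand for stronger inhibition of growth and higher numbers for weaker inhibition of growth:
- compound 1 `CCOC(=O)/C=C/c1ccncc1-c1ccc2c(cnn2C)c1`: 1330 nM
- compound 2 `NNC(=O)CCc1ccncc1-c1ccc2ccccc2c1`: > 30000 nM (a limit)
- compound 3 `O=C(CCc1ccncc1-c1ccc2ccccc2c1)N1CCOCC1`: > 30000 nM (a limit)

Compound 2 has no exact number in this assay, only the limit > 30000 nM. Compound 3 is also reported only as a limit, > 30000 nM. This is the situation described by the limit of > 30000 nM in this assay, at which 2 of the 3 values shown sit.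

The change to be followed leads to compound 4 `COC(=O)/C=C/c1ccncc1-c1ccc2ccccc2c1`: 2-(methoxycarbonyl)ethenyl in place of 2-(aminocarbamoyl)ethyl on an aromatic carbon. In words, 2-(methoxycarbonyl)ethenyl takes the place of 2-(aminocarbamoyl)ethyl on an aromatic carbon, while the core of compound 2 stays as it is.

Among the measured compounds shown here, the one measured step between close relatives, a step that the two limits leave unreadable from compound 2 to compound 3, gives no size to carry over, and it concerns only the group on the carbonyl carbon. The better guide is compound 1, which also carries an ester on an ethenyl chain, although its core differs from that of compound 4. In this assay, for the measured compounds named here, compound 1 gives 1330 nM, the only exact number available.

On that single comparison, a step beyond the usual scatter is expected, towards stronger inhibition of growth. The estimated change is an at least 15-fold lower number from compound 2 to compound 4 (1.17 log units; beyond the scatter), and its size stays uncertain since compound 2 is known only as a limit. Compound 4 is expected at 2000 nM, with an estimated range of 400 nM to 10000 nM.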

Compound 4, concentration for 50% growth inhibition: 350 nM
Compound 4: the middle estimate sits 5.7-fold (0.76 log units) above what was measured; measured number below the stated range.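

In this assay, the core of compound 2 first gives a readable value once 2-(methoxycarbonyl)ethenyl stands on this aromatic carbon, ortho to a large group and opposite the ring nitrogen, with an at least 85-fold lower number from compound 2 to compound 4 (1.93 log units; beyond the scatter). Among the compounds shown here, the earlier compounds on this core showed only that two groups ending in a carbonyl on a saturated chain left growth inhibition out of reach of the assay, whereas this step shows that the position responds strongly to what is attached to it. The true size of the step remains unknown because compound 2 is reported only as a limit: the limit of > 30000 nM in this assay, at which 2 of the 4 values shown sit.

The change replaces the saturated chain with an ethenyl chain and the hydrazide end with a methyl ester at once, so the compounds shown leave open which of the two accounts for the step. A 2-(methoxycarbonyl)ethyl group would separate the two, and a carboxylic acid or a morpholine amide on the ethenyl chain would show how much depends on the ester itself.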